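Removing One Methoxy Group: What to Expect for Compound 4

The source may hold more compounds than are shown below. What is called first, only, known or untested is meant among the compounds shown, and "the series" means these compounds.

Compound 1 `COc1cc(-c2cc(/C=C/C(=O)c3ccc(N)cc3)[nH]n2)cc(OC)c1OC` and compound 2 `COc1ccc(C(=O)/C=C/c2cc(-c3cc(OC)c(OC)c(OC)c3)n[nH]2)cc1OC` share a core, and the difference between the two cores is 4-aminophenyl in place of 3,4-dimethoxyphenyl on a carbonyl carbon. In a functional assay on UO-31 cells (Homo sapiens) for cytotoxicity, read by sulforhodamine B assay, with a stated time of 48 h, tested at 100 uM (a higher number here means a weaker effect of the compound at the concentration tested, a lower number a stronger effect), compound 1 gives -93%, while compound 2 gives -96%, so the step of a number 3 percentage points lower from compound 1 to compound 2 (within the scatter). Compound 3 `COc1ccc(C(=O)/C=C/c2cc(-c3cc(OC)c(OC)c(OC)c3)n[nH]2)cc1` gives -79% in this assay, and the step of a number 17 percentage points higher from compound 2 to compound 3 (beyond the scatter) follows the change (hydrogen in place of methoxy on an aromatic carbon). Compound 4 `COc1ccc(-c2cc(/C=C/C(=O)c3ccc(N)cc3)[nH]n2)cc1OC` has not been measured in this assay; it arises from compound 1 through (hydrogen in place of methoxy on an aromatic carbon). Its place differs only in also being meta to a methoxy group (2 heavy atoms), so this is the same kind of change, not the same. A step of a number 15 percentage points higher from compound 1 to compound 4 (beyond the scatter) is expected, resting on the modest size of a number 17 percentage points higher from compound 2 to compound 3 (beyond the scatter). Compound 4 is therefore estimated at -78%, with a likely range from -92% to -60%.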

Compound 4, a percentage reported as activity, at one concentration (the size of the read-out at that concentration, not a potency): -85%
Compound 4: the middle estimate sits 7 percentage points above what was measured; the range from low to high includes it.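

In this assay, taking away the methoxy group gives a number 8 percentage points higher from compound 1 to compound 4 (within the scatter). Set beside the earlier case of the same change, this step shows no real difference in size: the same change on two cores in this assay, a number 17 percentage points higher (beyond the scatter) from compound 2 to compound 3 and a number 8 percentage points higher (within the scatter) from compound 1 to compound 4, 9 percentage points apart, within the scatter of two such steps. The change therefore carried across these two cores with a similar size, but two cores are a small sample, and one step lies beyond the scatter while the other lies within it, so this does not show that the change would behave alike on other cores.

Only methoxy and hydrogen appear at this place, which leaves open what a hydroxyl group, a fluorine atom or an ethoxy group would do there. Also open, as far as these compounds go, is how these compounds compare at lower concentrations.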